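The compounds below may be only part of what the source reports. "The series", "measured", "known", "first", "only" and "open" are said of these compounds alone.

Series notes. Compound 1 `O=C1CSC(c2ccc(O)cc2)N1CCN1CCCCC1` in an ADME assay on Vero cells (Chlorocebus sabaeus) for cytotoxicity, read by neutral red uptake, tested at 25 ug/mL (a lower number here means a stronger effect, a higher number a weaker effect of the compound at the concentration tested), gives 100%. For the measured compounds named here, compound 2 `O=C1CSC(c2ccc(F)cc2)N1CCN1CCCCC1` stands level with compound 1 at the digits reported; in this assay compound 2 gives 100%; the only measured step, no change at the digits printed from compound 1 to compound 2 (within the scatter), exchanges fluoro for hydroxy on an aromatic carbon and sits within the scatter. Compound 3 `O=C1CSC(c2ccc(Cl)cc2)N1CCN1CCCCC1` has not yet been measured in this assay. Its difference from compound 2 is chloro in place of fluoro on an aromatic carbon. Going by the values given here, the single step that bears on this exchange is no change at the digits printed from compound 1 to compound 2 (within the scatter), which swapped one group at the same aromatic carbon and moved the read-out by nothing beyond the scatter. A second swap at the same place is expected to behave the same way. For compound 3 the expected step is no change at the digits printed from compound 2 to compound 3 (within the scatter), none beyond the scatter. Compound 3 is therefore estimated at 100% in this assay, within 85% to 100%.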

Compound 3, a percentage reported as activity, at one concentration (the size of the read-out at that concentration, not a potency): 84%
The estimate for compound 3 lay 16 percentage points above the measured number, and the stated range ends above it.
By their numbers in this assay, from the lowest: compound 3; then compounds 1 and 2 (each within the scatter of the next).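

In this assay, chloro in place of fluoro on the aromatic carbon gives a number 16 percentage points lower from compound 2 to compound 3 (beyond the scatter), and chloro in place of hydroxy gives a number 16 percentage points lower from compound 1 to compound 3 (beyond the scatter). The exchange of hydroxy for fluoro had suggested that this position was indifferent to its group, but the read-out does respond here, and among the three groups only chloro stands apart, with hydroxy and fluoro level with each other. Nothing available accounts for this separation of chloro from the other two groups.

As far as these compounds go, whether the shift stays with chloro alone or extends to other groups on the same carbon, such as bromo, methyl or methoxy, remains open. Also open, from the compounds shown here alone, is whether chloro gives a step of this size when the piperidine is replaced by another amine, such as morpholine.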